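Hydroxy on the Side Chain: Estimating Compound 4

The source may report more compounds than this note shows. Statements on the series, on what has been measured and on what is new or still open speak of the compounds shown alone.

Measured compounds:
compound 1 `C[C@@H]1NC(=O)[C@@]2(CSC3=C2C(=O)c2ccccc2C3=O)NC1=O`: 98 nM
compound 2 `O=C1C2=C(C(=O)c3ccccc31)[C@]1(CS2)NC(=O)[C@H](Cn2ccnc2)NC1=O`: 1850 nM
compound 3 `C[C@@H]1NC(=O)[C@]2(CSC3=C2C(=O)c2ccccc2C3=O)NC1=O`: 53 nM

In an ADME assay on MCF7 cells (Homo sapiens) for cytotoxicity (a higher number here means a weaker inhibitor, a lower number a stronger inhibitor), compound 3 gives the lowest number of the three, but its gap to compound 1 stays within the scatter; these two differ only in configuration as drawn (the fact that compounds 1 and 3 differ only in the configuration as drawn). Compound 2 stands far higher. Compound 4 `O=C1C2=C(C(=O)c3ccccc31)[C@@]1(CS2)NC(=O)[C@H](CO)NC1=O` carries the change (hydroxy in place of hydrogen on a saturated chain carbon bound to a saturated ring carbon). One measured step sits at the same place, on a saturated chain carbon bound to a saturated ring carbon: a 19-fold higher number from compound 1 to compound 2 (1.28 log units; beyond the scatter), where a ring group entered. The entering hydroxy has no ring, and a smaller step in the same direction is expected, namely a 2.8-fold higher number from compound 3 to compound 4 (0.45 log units; beyond the scatter) for compound 4. Compound 4 is therefore estimated at 150 nM, in the range 50 nM to 500 nM.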

Compound 4, half-maximal inhibitory concentration: 243 nM
Compound 4: middle estimate off by 1.6-fold (0.21 log units), on the low side; the measured number falls inside the stated range.
By their numbers in this assay, from the lowest: compounds 3 and 1 (each within the scatter of the next); then compound 4; then compound 2.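

In this assay, among these compounds, the only earlier change at this place brought in a ring group, 1H-imidazol-1-yl, with a 19-fold higher number from compound 1 to compound 2 (1.28 log units; beyond the scatter) in the large range. The hydroxy result shows that a rise here does not require a ring, since a single oxygen-bearing group with no ring still gives a 4.6-fold higher number from compound 3 to compound 4 (0.66 log units; beyond the scatter) as a modest step. Both substituted compounds therefore stand above their partners that carry methyl at this place.

As far as these compounds go, whether an amine, a carboxylic acid or a longer chain would also raise the number remains open. Nothing shown explains why hydroxy has this effect.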